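Weak inhibitors on a fused pyrimidine series

A few compounds are considered here, and "the series" means these few. Any claim that something is new, unique, unknown or untested is made for them only; others in the source may bear on it.

Measured so far:
compound 1 `Nc1nc(O)c2nc(-c3cccc4ccccc34)cnc2n1` — > 500000 nM
compound 2 `Nc1nc(O)c2nc(-c3ccc(F)cc3)cnc2n1` — > 500000 nM
compound 3 `Nc1nc(NCC2CCCCC2)c2c(n1)NCC(c1ccc(Cl)cc1)N2` — 214000 nM

In an assay on isolated protein for inhibition of Nitric oxide synthase, inducible (Homo sapiens), with a stated time of 30 min (on this read-out lower numbers stand for stronger inhibition and higher numbers for weaker inhibition), compound 1 gives > 500000 nM, which is a limit of the assay and not a number. Compound 2 likewise returns > 500000 nM, again a limit. Among the measured compounds shown here, compound 3 is the only compound with a measured number, 214000 nM. For the measured compounds named here, compounds 1 and 2 both sit at the limit of > 500000 nM in this assay, at which 2 of the 3 values shown sit, so no step between measured compounds can be set out and no trend drawn.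

Compound 4 `Nc1nc2c(c(N3CCCCC3)n1)NC(c1ccc(Cl)cc1)CN2` differs from compound 3 in one place: piperidin-1-yl in place of (cyclohexylmethyl)amino on an aromatic carbon. Going by the values given here, with only one number in hand there is no measured step to lean on. Since compound 3 already stands at 214000 nM, the expectation is for a step of a 1.6-fold higher number from compound 3 to compound 4 (0.21 log units; within the scatter) that is small, at most a modest loss of potency and quite possibly none beyond the scatter. Compound 4 is therefore estimated at 350000 nM, within 100000 nM to 1000000 nM, with a real chance that only a limit is reported.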

Compound 4, half-maximal inhibitory concentration: 106000 nM
Beside the measured number, compound 4's estimate is 3.3-fold (0.52 log units) above it; low and high end bracket the measured number.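

In this assay, among the compounds shown here, replacing (cyclohexylmethyl)amino with piperidin-1-yl on this aromatic carbon gives the only readable step: a 2.0-fold lower number from compound 3 to compound 4 (0.31 log units; beyond the scatter). For the compounds shown here, the place therefore responds to the choice of group, which the earlier compounds could not show, and the number does not rise when the hydrogen-bond donor counted in (cyclohexylmethyl)amino is absent from piperidin-1-yl. This single step cannot separate the loss of that donor from the change in ring and size, and both compounds remain weak inhibitors.

From the compounds shown here alone, whether morpholin-4-yl or a dimethylamino group at this place would move the number further remains open, as does whether the step would hold with an aryl group other than 4-chlorophenyl on the shared core. No step involving compound 1 or compound 2 can be read, as their values are limits and not numbers: the limit of > 500000 nM in this assay, at which 2 of the 4 values shown sit.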